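Hydroxypyridinone series: methyl on the chain carbon

The compounds below may be only part of what the source reports. "The series", "measured", "known", "first", "only" and "open" are said of these compounds alone.

Measured so far:
compound 1 `O=c1ccn(CCN2CCCCC2)c(CO)c1O` — 7.43
compound 2 `Cc1c(O)c(=O)ccn1CCN(C)C` — 7.02
compound 3 `CC(O)c1c(O)c(=O)ccn1CCN1CCCCC1` — 7.35

In a physicochemical assay for acid dissociation, read by spectrophotometry, compound 2 stands lowest of the three measured numbers, with compound 3 and compound 1 both beyond the scatter above it. The difference between the core of compound 1 and the core of compound 2 is not broken down here.

Compound 4 `CCc1c(O)c(=O)ccn1CCN(C)C` is the unmeasured member. It differs from compound 2 by methyl in place of hydrogen on a saturated chain carbon bound to an aromatic carbon. The same kind of change has been made once before, from compound 1 to compound 3, as methyl in place of hydrogen on a saturated chain carbon bound to an aromatic carbon and an oxygen on a saturated carbon; there the place also carries an oxygen on a saturated carbon, which is not so in compound 4. That earlier step gave a number 0.08 log units lower from compound 1 to compound 3 (within the scatter).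

Resting on that earlier step, the step for compound 4 is expected to be a number 0.04 log units lower from compound 2 to compound 4 (within the scatter), small and within the scatter. Compound 4 is therefore estimated at 6.98, between 6.73 and 7.23.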

Compound 4, acid dissociation constant: 7.16
Beside the measured number, compound 4's estimate is 0.18 log units below it; the measured number falls inside the stated range.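

In this assay the change gives a number 0.14 log units higher from compound 2 to compound 4 (within the scatter) and, on the other core, where the place also carries an oxygen on a saturated carbon, gives a number 0.08 log units lower from compound 1 to compound 3 (within the scatter) on the earlier step. Neither step stands clear of the scatter, so the change can be carried between these two cores without a shift that can be told from scatter, but the printed signs give no direction to carry, and two pairs do not establish a rule for the series. No evidence bearing on either step is at hand.

As far as these compounds go, a longer chain, such as propyl, or an amine at this place remains open. So does whether any such group would move the number beyond the scatter on either core.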